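The compounds below may be only part of what the source reports. "The series", "measured", "known", "first", "only" and "open" are said of these compounds alone.

Measured compounds:
- compound 1, `O=C(O)CCc1ccc(-c2ccc3cnn(-c4ccccn4)c3c2)cc1`, 4500 nM
- compound 2, `Cc1cc(-c2ccc(CCC(=O)O)cc2)cc2c1cnn2-c1ccccn1`, 2600 nM

In a functional assay on cells for agonist activity at Free fatty acid receptor 1 (Mus musculus), read by FLIPR and calcium flux, with a stated time of 5 min (on this read-out higher numbers stand for an effect only at larger amounts of compound and lower numbers for an effect already at smaller amounts), compound 2 gives the lowest of the two numbers; its nearest neighbour is compound 1, and the step of a 1.7-fold lower number from compound 1 to compound 2 (0.24 log units; within the scatter) lies within the scatter. Compound 3, `O=C(O)CCc1ccc(-c2cc(F)c3cnn(-c4ccccn4)c3c2)cc1`, differs from compound 2 by fluoro in place of methyl on an aromatic carbon. No measured step swaps these two groups directly; the only shown step, a 1.7-fold lower number from compound 1 to compound 2 (0.24 log units; within the scatter), changed the same position and stayed within the scatter, so compound 3 is expected to show no step beyond the scatter: a 1.2-fold higher number from compound 2 to compound 3 (0.06 log units; within the scatter). Compound 3 is estimated at 3000 nM, between 1400 nM and 6500 nM.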

Compound 3, half-maximal effective concentration in the Free fatty acid receptor 1 assay: 2600 nM
For compound 3 the middle estimate is 1.2-fold (0.06 log units) above the measured one, and the stated range covers the measured number.
By their numbers in the Free fatty acid receptor 1 assay, from the lowest: compounds 2, 3 and 1 (each within the scatter of the next).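

In the Free fatty acid receptor 1 assay compound 2 gives 2600 nM and compound 3 gives 2600 nM, so the swap gives no change at the digits printed from compound 2 to compound 3 (within the scatter) and, against the unsubstituted compound, fluoro gives a 1.7-fold lower number from compound 1 to compound 3 (0.24 log units; within the scatter) here, so hydrogen, methyl and fluoro on this aromatic carbon cannot be told apart. In a physicochemical assay for lipophilicity, using the shake flask method, measured as octanol-water partition, with a stated time of 30 min, at pH 7.4 (on this read-out lower numbers stand for lower lipophilicity and higher numbers for higher lipophilicity), compound 2 gives 2.6 and compound 3 gives 2.8; the swap from methyl to fluoro shows a number 0.20 log units higher from compound 2 to compound 3 (within the scatter) and so separates these two compounds no better. Nothing available explains why these small groups read alike. Still open, going by these compounds, is whether a larger group on this carbon, such as trifluoromethyl, methoxy or an amine, would shift either number beyond the scatter.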